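This account rests on a few compounds, and the source may have more. Where it says the series, first, only, none or still open, it means among the compounds named here.

Series notes, values from a functional assay on HepG2 cells (Homo sapiens) for antiproliferative activity, read by XTT assay, with a stated time of 72 h; a higher number here means a weaker inhibitor, a lower number a stronger inhibitor (each a limit, not a number):

compound 1 `CSc1ncnc2c1c(-c1ccsc1)cn2[C@@H]1O[C@H](CO)[C@@H](O)[C@H]1O` gives > 15000 nM as a limit
compound 2 `CNc1ncnc2c1c(-c1ccoc1)cn2[C@@H]1O[C@H](CO)[C@@H](O)[C@H]1O` gives > 20000 nM as a limit
compound 3 `Nc1nc2c(c(-c3ccoc3)cn2[C@@H]2O[C@H](CO)[C@@H](O)[C@H]2O)c(=O)[nH]1` gives > 20000 nM as a limit

Compound 3 stands at the limit of > 20000 nM in this assay, at which 2 of the 3 values shown sit, and so has no numerical potency to compare. Going by the values given here, none of the three compounds gives a number in this assay and no step between measured compounds is available, so the series offers no measured size of change for a single structural edit.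

The next compound is compound 4 `Nc1nc2c(c(-c3ccccc3)cn2[C@@H]2O[C@H](CO)[C@@H](O)[C@H]2O)c(=O)[nH]1`, which has phenyl in place of furan-3-yl on an aromatic carbon and otherwise matches compound 3. Among the compounds with values here, the expectation rests mainly on compound 3, whose limit of > 20000 nM is the only anchor for this step. No shift beyond the usual scatter is expected, and no direction is favoured. The estimated change is a number no higher from compound 3 to compound 4 (the limit leaves the size open) in this assay and should be read with that anchor in mind. A report of compound 4 as another limit is the expected outcome. For compound 4 the estimated value is 20000 nM within an expected range of 9000 nM to 40000 nM in this estimate.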

Compound 4, half-maximal inhibitory concentration: > 20000 nM
Compound 4 ended at the assay's limit; the forecaster's own chance of this, stated with the estimate: 85%; the middle value sits exactly at the limit.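

In this assay, compound 3 and compound 4 both give limits rather than numbers, so the exchange of furan-3-yl for phenyl yields no readable step. Compound 4 rests at a limit: the limit of > 20000 nM in this assay, at which 3 of the 4 values shown sit.

The compounds shown leave open whether any change to this series would give a numerical half-maximal inhibitory concentration in this assay.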